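Losing the side chain from compound 2

The source may report more compounds than this note shows. Statements on the series, on what has been measured and on what is new or still open speak of the compounds shown alone.

In a functional assay on SH-SY5Y cells (Homo sapiens) for cytotoxicity, read by MTT assay, with a stated time of 72 h (on this read-out lower numbers stand for stronger inhibition and higher numbers for weaker inhibition), compound 1 `O=C1c2c[n+]([O-])c3ccccc3c2C(=O)c2c1c1ccccc1n2CCCCN1CCNCC1` gives 1240 nM and compound 2 `CN1CCN(CCCCCn2c3c(c4ccccc42)C(=O)c2c[n+]([O-])c4ccccc4c2C3=O)CC1` gives 830 nM on the same read-out, so these two sit within the scatter of each other. Compound 3 `O=C1c2c[n+]([O-])c3ccccc3c2C(=O)c2[nH]c3ccccc3c21` follows from compound 2 through hydrogen in place of 5-(4-methylpiperazin-1-yl)pentyl on an aromatic nitrogen and so carries hydrogen in place of 5-(4-methylpiperazin-1-yl)pentyl on an aromatic nitrogen. Among the measured compounds shown here, the one measured step is a 1.5-fold lower number from compound 1 to compound 2 (0.17 log units; within the scatter) and it leaves a chain in place, so it says little about losing the whole chain. A higher number is expected, estimated as a 3.0-fold higher number from compound 2 to compound 3 (0.48 log units; beyond the scatter) with wide uncertainty. In this assay compound 3 is estimated at 2500 nM with an expected range of 400 nM to 15000 nM for that measurement.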

Compound 3, half-maximal inhibitory concentration: 1380 nM
Estimate against measurement, compound 3: 1.8-fold (0.26 log units) above, within the range that was stated.
By their numbers in this assay, from the lowest: compounds 2, 1 and 3 (each within the scatter of the next).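

Taking the side chain off the aromatic nitrogen altogether gives a 1.7-fold higher number from compound 2 to compound 3 (0.22 log units; within the scatter) in this assay, and set against the 4-(piperazin-1-yl)butyl group it gives a 1.1-fold higher number from compound 1 to compound 3 (0.05 log units; within the scatter). The shared core with only hydrogen on that nitrogen thus stays within the scatter of both compounds with a chain, so neither chain is required for the cytotoxicity seen here. Nothing available explains this result. Open, as far as these compounds go, is whether a small methyl group on that nitrogen, or a chain ending in morpholine or a carboxylic acid, would separate from these values.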